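From chloromethyl to prop-1-en-1-yl on the carbonyl

This account rests on a few compounds, and the source may have more. Where it says the series, first, only, none or still open, it means among the compounds named here.

In a functional assay on Maver1 cells (Homo sapiens) for inhibition, read by luminescence and CellTiter-Glo, with a stated time of 72 h (a higher number here means a weaker inhibitor, a lower number a stronger inhibitor), compound 1 (`O=C(CCl)N1CCCC(n2nc(-c3ccc(Oc4ccccc4)cc3)cc2CO)C1`) gives 1100 nM, the second highest of three numbers. Compound 2 (`O=C(O)c1cc(-c2ccc(Oc3ccccc3)cc2)nn1C1CCCN(C(=O)CCl)C1`) gives 400 nM, and compound 3 (`C/C=C/C(=O)Nc1cccc(Cn2nc(-c3ccc(Oc4ccccc4)cc3)cc2CO)c1`) gives 8100 nM. Compound 4 (`C/C=C/C(=O)N1CCCC(n2nc(-c3ccc(Oc4ccccc4)cc3)cc2CO)C1`) has not yet been measured. It departs from compound 1 by one change, (prop-1-en-1-yl in place of chloromethyl on a carbonyl carbon), which puts prop-1-en-1-yl in place of chloromethyl on a carbonyl carbon.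

For the measured compounds named here, the only measured step, a 2.8-fold lower number from compound 1 to compound 2 (0.44 log units; beyond the scatter), is modest and swaps carboxy for hydroxymethyl on an aromatic carbon, so it says little about this change. Going by the values given here, no measured step alters the group on the carbonyl. Compound 3 also carries prop-1-en-1-yl on a carbonyl carbon, though on a different core, and its 8100 nM is a higher number than that of compound 1. This is thin evidence, but it points towards a weaker inhibitor in this assay. The expected change is a 2.3-fold higher number from compound 1 to compound 4 (0.36 log units; beyond the scatter). Compound 4 is estimated at 2500 nM, with an expected range from 1000 nM to 7000 nM.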

Compound 4, half-maximal inhibitory concentration: > 60000 nM
Compound 4 was reported as a limit; the forecaster's own chance of this, stated with the estimate: 3%; at least 24-fold (1.38 log units) between middle value and limit.
By their numbers in this assay, from the lowest: compound 2; then compound 1; then compound 3. At a limit, above all of these: compound 4.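

In this assay, the group on this carbonyl carbon proves decisive on the core of compound 1: with the amide-type nitrogen in a ring as its other neighbour, prop-1-en-1-yl in place of chloromethyl gives an at least 54-fold higher number from compound 1 to compound 4 (1.73 log units; beyond the scatter). For the compounds shown here, the earlier compounds could not show this, since the only earlier step, a 2.8-fold lower number from compound 1 to compound 2 (0.44 log units; beyond the scatter), left the carbonyl group untouched. The reading for compound 4 is a limit of the assay and not a number, so the true size of the step stays undetermined: the limit of > 60000 nM in this assay, at which 1 of the 4 values shown sits.

Going by these compounds, how an ethenyl group, a longer chain or a chain bearing an amine would read on this carbonyl remains open. Also open, on these data alone, is whether carboxy in place of hydroxymethyl would shift compound 4 as it shifted compound 1.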